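The compounds below may be only part of what the source reports. "The series", "measured", "known", "first", "only" and "open" are said of these compounds alone.

Working notes on the series. Of the compounds shown here, two sharing one core have been measured in a functional assay on B16-F10 cells (Mus musculus) for inhibition, read by MTT assay, with a stated time of 72 h; a higher number here means a weaker inhibitor, a lower number a stronger inhibitor. Compound 1 `COc1cc(-c2nc(SCc3cn(CC(=O)NC(=O)Nc4ccccn4)nn3)nc(Nc3ccc(C)cc3)c2C#N)cc(OC)c1OC` gives 32 nM in this assay. Compound 2 `COc1ccc(Nc2nc(SCc3cn(CC(=O)NC(=O)Nc4ccccn4)nn3)nc(-c3ccc(C)cc3)c2C#N)cc1` gives 8750 nM in this assay, the higher of the two numbers, and the gap to compound 1 lies beyond the usual scatter. Within the data shown here, the two compounds differ in more than one place at once, so no single-point step between measured compounds is available.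

Compound 3 `Cc1ccc(Nc2nc(SCc3cn(CC(=O)NC(=O)Nc4ccccn4)nn3)nc(-c3ccc(C)cc3)c2C#N)cc1` is the next compound, not yet measured. It differs from compound 2 in one place: methyl in place of methoxy on an aromatic carbon. Among the measured compounds shown here, no measured pair shows this exact change, so the direction is uncertain. A step of modest size is expected from compound 2 to compound 3 in this assay, a 1.8-fold lower number from compound 2 to compound 3 (0.24 log units; within the scatter), possibly within the scatter. Compound 3 is accordingly estimated at 5000 nM in this assay, with a range from 1500 nM to 20000 nM.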

Compound 3, half-maximal inhibitory concentration: 1010 nM
Compound 3: the middle estimate sits 5.0-fold (0.69 log units) above what was measured; measured number outside the range, below it.
By their numbers in this assay, from the lowest: compound 1; then compound 3; then compound 2.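

In this assay, among these compounds, (4-methylphenyl)amino in place of (4-methoxyphenyl)amino gives an 8.7-fold lower number from compound 2 to compound 3 (0.94 log units; beyond the scatter), the first single-place reading at this position, and it shows that the number responds to the swap of methoxy for methyl para to a large group. At the other aryl group, 4-methylphenyl in place of 3,4,5-trimethoxyphenyl gives a 32-fold higher number from compound 1 to compound 3 (1.50 log units; beyond the scatter), so the gain from the methyl leaves compound 3 well short of compound 1. No measurement on hand accounts for either step.

As far as these compounds go, whether a chlorine or an amine at the same place would carry the number further remains open. Also open, from the compounds shown here alone, is whether the methoxy-to-methyl step holds its size when 3,4,5-trimethoxyphenyl, rather than 4-methylphenyl, sits on the shared core.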